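The compounds below may be only part of what the source reports. "The series", "measured", "known", "first", "only" and "open" are said of these compounds alone.

Compound 1 `COc1cc2ncnc(Nc3ccc(NC(=O)c4ccc(C(C)(C)C)cc4)cc3)c2cc1OC` reads > 100000 nM in a functional assay on MCF7 cells (Homo sapiens) for inhibition, read by MTT assay (a lower number here means a stronger inhibitor, a higher number a weaker inhibitor), and this is a limit, not a number. Going by the values given here, compound 2 `COc1cc2ncnc(Nc3ccc(NC(=O)c4cccc(I)c4)cc3)c2cc1OC` gives 30000 nM in this assay, the only true number so far, so its standing rests on a single comparison with the limit of > 100000 nM in this assay, at which 1 of the 2 values shown sits.

The next compound, compound 3 `COc1cc2ncnc(Nc3ccc(NC(=O)c4ccc(I)cc4)cc3)c2cc1OC`, moves the iodine: 4-iodophenyl in place of 3-iodophenyl on a carbonyl carbon. That is 4-iodophenyl in place of 3-iodophenyl on a carbonyl carbon.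

Among the compounds with values here, only one measured step bears on this, an at least 3.3-fold lower number from compound 1 to compound 2 (0.52 log units; beyond the scatter). It replaced 4-(tert-butyl)phenyl with 3-iodophenyl, so it changed the group and its placement together and cannot separate the two. Compound 3 keeps the iodine of compound 2 but shares the 4-substituted pattern of compound 1, which reads > 100000 nM. On that slim basis, a small move in this assay towards a higher number is expected, probably not beyond the scatter, and a reading at the limit remains possible.

The estimated change is a 1.7-fold higher number from compound 2 to compound 3 (0.22 log units; within the scatter).

For compound 3 the expected value is 50000 nM, with an estimated range of 15000 nM to 100000 nM.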

Compound 3, half-maximal inhibitory concentration: 48000 nM
Compound 3: middle estimate off by 1.0-fold (0.02 log units), on the high side; the measured number falls inside the stated range.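

In this assay, going by these compounds alone, the iodine move gives a 1.6-fold higher number from compound 2 to compound 3 (0.20 log units; within the scatter), so 3-iodophenyl and 4-iodophenyl on the carbonyl carbon cannot be told apart here, and this is the first comparison to hold the group fixed and change only its placement. The second new step holds the placement and changes only the group, iodo in place of tert-butyl on an aromatic carbon, giving an at least 2.0-fold lower number from compound 1 to compound 3 (0.31 log units; beyond the scatter), which shows that the group alone can produce a step beyond the scatter, something the earlier step, with group and placement changed together, could not separate. The true size of that step is unknown, as compound 1 stands as a limit, not a number: the limit of > 100000 nM in this assay, at which 1 of the 3 values shown sits.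

Still open, going by these compounds, is whether a group other than iodo or tert-butyl on this ring, such as an amine or a carboxylic acid, would give a step beyond the scatter from compound 2 or compound 3. Within the data shown here, also open is whether placement stays without a readable step for other groups, such as tert-butyl or a longer chain, since the only pair that isolates placement carries iodine.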